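A 3-cyanophenyl swap in a series at its limit

The source may report more compounds than this note shows. Statements on the series, on what has been measured and on what is new or still open speak of the compounds shown alone.

Measured so far in an ADME assay on Karpas-1106P cells (Homo sapiens) for cytotoxicity; a lower number here means that less compound is needed, a higher number that more compound is needed for the effect:
Compound 1 `Cc1ccc(S(=O)(=O)N[C@@H](CC(=O)NC(C)(C)C)C(=O)NCCNC(=O)c2cc(Cl)ccn2)cc1` gives > 11100 nM as a limit
Compound 2 `Cc1ccc(S(=O)(=O)N[C@@H](CC(=O)NC(C)(C)C)C(=O)NCCNC(=O)c2c(O)cccc2F)cc1` gives > 11100 nM as a limit
Compound 3 `COc1cc(OC)cc(C(=O)NCCNC(=O)[C@H](CC(=O)NC(C)(C)C)NS(=O)(=O)c2ccc(C)cc2)c1` gives > 11100 nM as a limit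

Compound 2 stands at a limit (> 11100 nM), not at a number. The other two measured compounds sit there as well (the limit of > 11100 nM in this assay, at which 3 of the 3 values shown sit). Compound 4 `Cc1ccc(S(=O)(=O)N[C@@H](CC(=O)NC(C)(C)C)C(=O)NCCNC(=O)c2cccc(C#N)c2)cc1` is still unmeasured. It carries 3-cyanophenyl in place of 2-fluoro-6-hydroxyphenyl on a carbonyl carbon.

The measured steps at that same place are (a step that the two limits leave unreadable from compound 1 to compound 2), (a step that the two limits leave unreadable from compound 1 to compound 3) and (a step that the two limits leave unreadable from compound 2 to compound 3). None has a readable size, yet three different groups there all end at the limit. No step beyond the scatter is therefore expected in this assay in either direction. The expected step is (a step that the limit leaves unreadable from compound 2 to compound 4). A report of only a limit is likely again for compound 4. Compound 4 is expected at 15000 nM within an estimated range (6000 nM to 40000 nM).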

Compound 4, half-maximal effective concentration: > 11100 nM
Compound 4 ended at the assay's limit (the forecaster's own chance of this, stated with the estimate: 85%); the middle value does not contradict the limit.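

In this assay compound 4 gives > 11100 nM as a limit and not a number. Among these compounds, no step between compound 4 and compound 1, compound 2 or compound 3 can be read: the limit of > 11100 nM in this assay, at which 4 of the 4 values shown sit.

The compounds shown leave open whether any group at this place gives a measurable effect.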